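Notes on the series: replacing the substituted phenyl of compound 2

This account rests on a few compounds, and the source may have more. Where it says the series, first, only, none or still open, it means among the compounds named here.

In a functional assay on HepG2 cells (Homo sapiens) for cytotoxicity, read by MTT assay, with a stated time of 72 h (a lower number here means a stronger inhibitor, a higher number a weaker inhibitor), compound 1 `COc1cc2ncnc(Nc3ccc(F)c(Cl)c3)c2cc1NC(=O)N/N=C/c1ccc(C#N)cc1` gives 34100 nM and compound 2 `CCN(CC)c1ccc(/C=N/NC(=O)Nc2cc3c(Nc4ccc(F)c(Cl)c4)ncnc3cc2OC)c(O)c1` gives 29300 nM. Compound 2 thus stands within the scatter of compound 1, and the two cannot be ranked. For the measured compounds named here, the only measured step, a 1.2-fold lower number from compound 1 to compound 2 (0.07 log units; within the scatter), came with 4-(diethylamino)-2-hydroxyphenyl in place of 4-cyanophenyl on a carbon with a double bond to nitrogen.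

Compound 3 `COc1cc2ncnc(Nc3ccc(F)c(Cl)c3)c2cc1NC(=O)N/N=C/c1ccc(O)cc1` carries 4-hydroxyphenyl in place of 4-(diethylamino)-2-hydroxyphenyl at that same place: 4-hydroxyphenyl in place of 4-(diethylamino)-2-hydroxyphenyl on a carbon with a double bond to nitrogen. Going by the values given here, the one measured step bears directly on this change, though a single step is thin support. No step beyond the scatter is expected in this assay, in either direction. The expected change is a 1.1-fold higher number from compound 2 to compound 3 (0.02 log units; within the scatter). Compound 3 is estimated at 31000 nM, with an expected range of 15000 nM to 65000 nM.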

Compound 3, half-maximal inhibitory concentration: 26300 nM
Estimate against measurement, compound 3: 1.2-fold (0.07 log units) above; the measured number falls inside the stated range.
By their numbers in this assay, from the lowest: compounds 3, 2 and 1 (each within the scatter of the next).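

In this assay, 4-hydroxyphenyl in place of 4-(diethylamino)-2-hydroxyphenyl on a carbon with a double bond to nitrogen gives a 1.1-fold lower number from compound 2 to compound 3 (0.05 log units; within the scatter), so these two groups cannot be told apart at this place. Hydroxy in place of cyano on an aromatic carbon gives a 1.3-fold lower number from compound 1 to compound 3 (0.11 log units; within the scatter), so the 4-hydroxyphenyl and 4-cyanophenyl groups cannot be told apart either. Across compound 1, compound 2 and compound 3, no aromatic group shown at this place separates from another, and no compound goes against this. Nothing at hand explains why these groups read alike. As far as these compounds go, whether an amine, a carboxylic acid or a longer chain at this place would give a step beyond the scatter stays open. From the compounds shown here alone, whether the same holds with other groups on the shared core also stays open.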